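Compound 2 to compound 4: iodo for trifluoromethyl

This account rests on a few compounds, and the source may have more. Where it says the series, first, only, none or still open, it means among the compounds named here.

In a functional assay on HCC827 cells (Homo sapiens) for antiproliferative activity, read by MTT assay, with a stated time of 48 h (a lower number here means a stronger inhibitor, a higher number a weaker inhibitor), compound 1 `Cc1cc(F)cc(Nc2cc(NC(=O)Nc3c(Cl)cccc3Cl)ncn2)c1` gives 18600 nM while compound 3 `COc1cc(Nc2cc(NC(=O)Nc3c(Cl)cccc3Cl)ncn2)cc(OC)c1` gives 13300 nM and compound 2 `COc1cc(NC(=O)Nc2cc(Nc3cc(C(F)(F)F)ccc3OC)ncn2)cc(OC)c1` gives 15100 nM in the same range. All three values lie within the scatter of one another, so compound 2 stands level with compound 1 and compound 3 on these numbers, and the three cannot be ranked.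

The change to compound 4 `COc1cc(NC(=O)Nc2cc(Nc3cc(I)ccc3OC)ncn2)cc(OC)c1` is iodo in place of trifluoromethyl on an aromatic carbon and amounts to iodo in place of trifluoromethyl on an aromatic carbon, meta to a large group and para to a methoxy group.

No two measured compounds differ in one place only, so the size of this step is not shown directly. Among the measured compounds shown here, the only guide is the narrow spread of the measured set, whose members differ in several places yet stay within the scatter, with compound 3 at 13300 nM and compound 1 at 18600 nM in this assay as well. On that basis no step beyond the scatter is expected in this assay and neither direction is favoured. The estimate amounts to a 1.1-fold lower number from compound 2 to compound 4 (0.03 log units; within the scatter) and is expected to stay within the scatter. In this assay compound 4 is expected at 14000 nM with an estimated range from 6000 nM to 30000 nM as the working figure.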

Compound 4, half-maximal inhibitory concentration: > 20000 nM
Compound 4 gave a limit, no number; the forecaster's own chance of this, stated with the estimate: 10%; middle value at least 1.4-fold (0.15 log units) from the limit.
By their numbers in this assay, from the lowest: compounds 3, 2 and 1 (each within the scatter of the next). At a limit, above all of these: compound 4.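

In this assay compound 4 gives > 20000 nM, which is a limit of the assay and not a number. This gives the series its first pair differing in one place, iodo in place of trifluoromethyl on an aromatic carbon, meta to a large group and para to a methoxy group, and the step reads an at least 1.3-fold higher number from compound 2 to compound 4 (0.12 log units; that floor lies within the scatter). The floor of that step lies within the scatter, so a real loss at this position is not established, and the size of the step has no upper bound, with the whole reading resting on a single limit: the limit of > 20000 nM in this assay, at which 1 of the 4 values shown sits.

Going by these compounds, the true value of compound 4 stays open, and with it whether this position responds to the change at all or whether the reading merely sits at the edge of the assay. Also open, on these data alone, is whether a different group at this position, such as an amine, a nitrile or a carboxylic acid, would give a value clearly apart from that of compound 2, which only a measured number on such a compound could settle.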